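Butyl for amino on the aryl of compound 2

The source may hold more compounds than are shown below. What is called first, only, known or untested is meant among the compounds shown, and "the series" means these compounds.

Measured compounds:
Compound 1, `CCCCc1ccc(-c2ccc3ncc(C(=O)OCC)cc3c2)cc1`; in a functional assay on RD cells (Homo sapiens) for inhibition, read by luminescence and ATP content, with a stated time of 72 h (on this read-out higher numbers stand for lower toxicity in this test and lower numbers for higher toxicity in this test), compound 1 gives > 7400 nM, a limit.
Compound 2, `Cc1nc(-c2cnc3ccc(-c4ccc(N)cc4)cc3c2)no1`; in this assay compound 2 gives > 2500 nM, a limit.
Compound 3, `CC(C)c1nc(-c2cnc3ccc(-c4ccc(N)cc4)cc3c2)no1`; in this assay compound 3 gives > 800 nM, a limit.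

Compound 2 stands only at a limit, as do both other values. For the measured compounds named here, the one single-point step, a step that the two limits leave unreadable from compound 2 to compound 3, is not readable between its two limits. Compound 4, `CCCCc1ccc(-c2ccc3ncc(-c4noc(C)n4)cc3c2)cc1`, differs from compound 2 by butyl in place of amino on an aromatic carbon. Going by the values given here, no measured step bears directly on this change; compound 1, which also carries butyl on that ring, sits at the limit (the limit of > 7400 nM in this assay, at which 1 of the 3 values shown sits). For compound 4 the step that the limit leaves unreadable from compound 2 to compound 4 is expected to stay within the scatter, with a limit likely again. Compound 4 is therefore estimated at 10000 nM, range 3000 nM to 30000 nM.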

Compound 4, half-maximal cytotoxic concentration: > 2500 nM
Compound 4 was reported as a limit; the forecaster's own chance of this, stated with the estimate: 75%; the middle value lies beyond the limit too.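

In this assay compound 4 gives > 2500 nM, a limit. For the compounds shown here, with compound 1 and compound 2 also at limits, no step to compound 4 can be read. The compounds shown leave open where the actual half-maximal cytotoxic concentration of any of the four lies.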